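This account rests on a few compounds, and the source may have more. Where it says the series, first, only, none or still open, it means among the compounds named here.

Compound 1 `COc1cccc(Oc2c(NS(=O)(=O)c3ccc(C(C)(C)C)cc3)ncnc2OCCO)c1`: 160 nM
Compound 2 `COCCOc1ncnc(NS(=O)(=O)c2ccc(C(C)(C)C)cc2)c1Oc1cccc(OC)c1`: 92 nM
Compound 3 `COc1cccc(Oc2c(NS(=O)(=O)c3ccc(C(C)(C)C)cc3)ncnc2OCCOCc2ccccc2)c1`: 170 nM

The three measured compounds share one core and differ only at the far end of a short chain that hangs from an oxygen on that core. In an assay on cells (Endothelial cell) for binding affinity to Endothelin-1 receptor (Sus scrofa) (a lower number here means a stronger inhibitor, a higher number a weaker inhibitor), compound 1 gives 160 nM, compound 2 gives 92 nM and compound 3 gives 170 nM. Compound 3 stands alongside the other two rather than apart from them: the step of a 1.1-fold higher number from compound 1 to compound 3 (0.03 log units; within the scatter) and the step of a 1.8-fold higher number from compound 2 to compound 3 (0.27 log units; within the scatter) both stay within the scatter, and so does a 1.7-fold lower number from compound 1 to compound 2 (0.24 log units; within the scatter). Compound 4 `COc1cccc(Oc2c(NS(=O)(=O)c3ccc(C(C)(C)C)cc3)ncnc2OCCOc2ccncn2)c1` differs from compound 3 by pyrimidin-4-yl in place of benzyl on an oxygen on a saturated carbon. Going by the values given here, every measured step so far altered this same terminal position, and none of them moved the number beyond the scatter, so the expectation for compound 4 in this assay is a step of a 1.3-fold lower number from compound 3 to compound 4 (0.12 log units; within the scatter), again not beyond the scatter. Compound 4 is therefore estimated at 130 nM, with a range from 50 nM to 350 nM.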

Compound 4, half-maximal inhibitory concentration: 1.2 nM
Beside the measured number, compound 4's estimate is 110-fold (2.03 log units) above it, outside the stated range (below it).
By their numbers in this assay, from the lowest: compound 4; then compounds 2, 1 and 3 (each within the scatter of the next).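

In this assay, this terminal position proves far from indifferent: hydrogen, methyl and benzyl on the oxygen all stay within the scatter of one another, yet pyrimidin-4-yl brings a 140-fold lower number from compound 3 to compound 4 (2.15 log units; beyond the scatter), along with a 77-fold lower number from compound 2 to compound 4 (1.88 log units; beyond the scatter) and a 130-fold lower number from compound 1 to compound 4 (2.12 log units; beyond the scatter). A six-membered aromatic ring at this place is not enough on its own, since compound 3 carries one and still stays with compound 1 and compound 2. The change from compound 3 to compound 4 does two things at once: it removes the saturated carbon of the benzyl group, placing the ring directly on the oxygen, and it brings two ring nitrogens.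

Going by these compounds, whether a plain phenyl or a pyridinyl ring on this oxygen would keep the large step remains open, so the two parts of the change cannot yet be separated. No measurement shown here explains why the number moves so far.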